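Working notes: hydrogen in place of methyl on compound 1

The source may hold more compounds than are shown below. What is called first, only, known or untested is meant among the compounds shown, and "the series" means these compounds.

Compound 1 `C=C1C[C@]23C[C@@]1(O)CC[C@@H]2c1cccc(C)c1[C@@H]3Cn1cc(-c2ccc(C)cc2)nn1` gives only a limit, > 20000 nM, in a functional assay on SMMC-7721 cells (Homo sapiens) for cytotoxicity, read by MTT assay, with a stated time of 4 days; on this read-out higher numbers stand for weaker inhibition and lower numbers for stronger inhibition.
Compound 2 `C=C1C[C@]23C[C@@]1(O)CC[C@H]2c1cc(Br)c(O)c(C)c1[C@@H]3Cn1cc(-c2ccc(C)cc2)nn1` gives a limit, > 20000 nM, in this assay.
Compound 3 `C=C1C[C@]23C[C@@]1(O)CC[C@H]2c1cc(Br)c(O)c(C)c1[C@@H]3Cn1cc(-c2ccccn2)nn1` gives a limit, > 20000 nM, in this assay.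

For the measured compounds named here, every value measured so far sits at the limit of > 20000 nM in this assay, at which 3 of the 3 values shown sit, so compound 1 stands at that limit together with the other two, and no order among the three can be read. Going by the values given here, the single step between measured compounds, a step that the two limits leave unreadable from compound 2 to compound 3, is a change between two limits and its size cannot be read; it also concerns a different position from the one of interest here.

Compound 4 `C=C1C[C@]23C[C@@]1(O)CC[C@@H]2c1cccc(C)c1[C@@H]3Cn1cc(-c2ccccc2)nn1` differs from compound 1 by hydrogen in place of methyl on an aromatic carbon. Among the compounds with values here, no measured step covers this change, so the only guide is that compound 1 sits at the limit, > 20000 nM. The change removes a single carbon, and compound 4 is therefore expected to stay at the limit, with the step that the limit leaves unreadable from compound 1 to compound 4 expected to be none beyond the scatter. The estimate for compound 4 in this assay is 30000 nM, with a range from 10000 nM to 100000 nM.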

Compound 4, half-maximal inhibitory concentration: > 20000 nM
Compound 4 was reported as a limit; the forecaster's own chance of this, stated with the estimate: 85%; the middle value does not contradict the limit.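

No step can be read between compound 1 and compound 4, as both stand only as limits. The compounds shown leave open whether any change to the shared core or its substituents would bring a value off the limit they all share: the limit of > 20000 nM in this assay, at which 4 of the 4 values shown sit.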